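The compounds below may be only part of what the source reports. "The series", "measured", "known", "first", "only" and "open" are said of these compounds alone.

Compound 2 `CN(c1ccc(Oc2ncnc3sccc23)cc1)c1nccc(N2CCCCC2)n1` stands lowest of the three compounds measured in a functional assay on A549 cells (Homo sapiens) for inhibition, read by MTT assay, with a stated time of 72 h, tested at 20 uM; on this read-out higher numbers stand for more inhibition at the one concentration tested (going by the name of the read-out) and lower numbers for less inhibition. In this assay compound 2 gives 51.9%, while compound 1 `CN(c1ccc(Oc2ncnc3sccc23)cc1)c1nccc(N2CCc3ccccc3C2)n1` gives 68.4% and compound 3 `c1cc(N2CCCCC2)nc(Nc2ccc(Oc3ncnc4sccc34)cc2)n1` gives 64.8%. The two steps between measured compounds both sit away from the oxygen-linked group: a number 16.5 percentage points lower from compound 1 to compound 2 (beyond the scatter), and a number 12.9 percentage points higher from compound 2 to compound 3 (beyond the scatter). Compound 4 `CN(c1ccc(Oc2ncnc3ccsc23)cc1)c1nccc(N2CCCCC2)n1` differs from compound 2 in that (a group of 9 heavy atoms (6 carbon, 2 nitrogen, 1 sulfur; one five-membered aromatic ring with 1 hetero atom, one six-membered aromatic ring with 2 hetero atoms) in place of a group of 9 heavy atoms (6 carbon, 2 nitrogen, 1 sulfur; one five-membered aromatic ring with 1 hetero atom, one six-membered aromatic ring with 2 hetero atoms), on an oxygen on an aromatic ring); the two have the same atoms, joined differently. Neither measured step touches the group on the oxygen, so there is no step in this series that speaks to this change, and the data give no reason to expect movement in either direction. The step from compound 2 to compound 4 is therefore expected to be a number 1.9 percentage points lower from compound 2 to compound 4 (within the scatter), which lies within the scatter. Compound 4 is estimated to give 50% in this assay, with a range from 30% to 70%.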

Compound 4, a percentage reported as inhibition, at one concentration (the size of the read-out at that concentration, not a potency): 65.7%
The estimate for compound 4 lay 15.7 percentage points below the measured number; the measured number falls inside the stated range.
By their numbers in this assay, from the lowest: compound 2; then compounds 3, 4 and 1 (each within the scatter of the next).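

Among these compounds, the group on an oxygen on an aromatic ring proves able to move this read-out: in this assay, the change gives a number 13.8 percentage points higher from compound 2 to compound 4 (beyond the scatter), where the earlier steps had said nothing about this place. The change is only a rejoining of the same atoms, since the leaving and entering groups have the same heavy atoms, the same ring sizes and the same counts of hydrogen-bond donors and acceptors, so a difference in how those atoms are joined is enough for a step beyond the scatter. Nothing available bears on why the rejoined group gives this step.

The compounds shown leave open whether the same change would give a similar step with 1,2,3,4-tetrahydroisoquinolin-2-yl in place of piperidin-1-yl, or with hydrogen in place of methyl on the nitrogen. They also leave open how an open-chain amine such as dimethylamino would behave in place of piperidin-1-yl.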